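Swapping an acetylated amine for a hydroxyl and dimethylamine

The source may report more compounds than this note shows. Statements on the series, on what has been measured and on what is new or still open speak of the compounds shown alone.

Of the compounds shown here, three sharing one core have been tested in an assay on HeLa cells for inhibition of sphingosine-1-phosphate transporter SPNS2 (Mus musculus), read by LC-MS, tested at 2 uM; a higher number here means more inhibition at the concentration tested (going by the name of the read-out), a lower number less inhibition. Compound 1 `CCCCCCCCCCc1ccc(-c2noc(C3CCNCC3)n2)cc1` gives 66%. Compound 2 `CCCCCCCCCCc1ccc(-c2noc([C@@H]3CCC[C@@H](N)C3)n2)cc1` gives 13%, a drop of a number 53 percentage points lower from compound 1 to compound 2 (beyond the scatter). Compound 3 `CCCCCCCCCCc1ccc(-c2noc(CC(CN)OC(C)=O)n2)cc1` gives 0%, the lowest of the three; the step of a number 66 percentage points lower from compound 1 to compound 3 (beyond the scatter) is large, and a number 13 percentage points lower from compound 2 to compound 3 (beyond the scatter) is modest.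

Compound 4 `CCCCCCCCCCc1ccc(-c2noc(CC(O)CN(C)C)n2)cc1` differs from compound 3 only in the group on the chain: a group of 6 heavy atoms (4 carbon, 1 nitrogen, 1 oxygen; no ring) in place of a group of 7 heavy atoms (4 carbon, 1 nitrogen, 2 oxygen; no ring), on a saturated chain carbon bound to an aromatic carbon. Among the compounds with values here, no measured step bears directly on this change; the two steps ending at compound 3 concern ring groups giving way to a chain, not an exchange of one chain group for another. Within the data shown here, they show only that the chain of compound 3 sits at the bottom. With compound 3 at the floor of the scale, a further fall is not possible, and a rise is not supported by any shown step. For compound 4 the expected step is therefore small, a number 10 percentage points higher from compound 3 to compound 4 (within the scatter), and compound 4 is estimated to give 10%, within a range from 0% to 35%.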

Compound 4, a percentage reported as inhibition, at one concentration (the size of the read-out at that concentration, not a potency): 61%
Compound 4: middle estimate off by 51 percentage points, on the low side, outside the stated range (above it).
By their numbers in this assay, from the lowest: compound 3; then compound 2; then compounds 4 and 1 (each within the scatter of the next).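

Compound 3 showed a chain at the bottom of the scale, but the chain itself does not fix the result: with the 2-(dimethylamino)-1-hydroxyethyl group on a saturated chain carbon bound to an aromatic carbon, the step is (a number 61 percentage points higher from compound 3 to compound 4 (beyond the scatter)). A ring is also not required at this position, as the step from the piperidin-4-yl compound is only (a number 5 percentage points lower from compound 1 to compound 4 (within the scatter)), whereas the step from the 3-aminocyclohexyl compound is (a number 48 percentage points higher from compound 2 to compound 4 (beyond the scatter)). No measurement shown here explains why the new group restores the reading.

On these data alone, two features changed together, the acetyl ester giving way to a hydroxyl and the primary amine to a dimethylamine, so their separate shares remain open. A chain carrying a hydroxyl with a primary amine would tell them apart.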